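Amino acid conjugates of a shared core: one chain homologation

The source may hold more compounds than are shown below. What is called first, only, known or untested is meant among the compounds shown, and "the series" means these compounds.

Measured so far in a functional assay on PC-12 cells (Rattus norvegicus) for inhibition, read by MTT assay; a lower number here means that less compound is needed, a higher number that more compound is needed for the effect:
compound 1 `CC1(C)N(O)C(c2ccc(OCC(=O)N[C@@H](CCCCN)C(=O)O)cc2)=[N+]([O-])C1(C)C` — compound 1 gives 99100 nM
compound 2 `CC1(C)N(O)C(c2ccc(OCCNC(=O)C[C@H](N)C(=O)O)cc2)=[N+]([O-])C1(C)C` — compound 2 gives 58200 nM

Compound 2 holds the lowest of the two numbers, but its nearest neighbour, compound 1, sits within the scatter, so the two cannot be ordered on these data. Compound 3 `CC1(C)N(O)C(c2ccc(OCCNC(=O)CC[C@H](N)C(=O)O)cc2)=[N+]([O-])C1(C)C` differs from compound 2 in a single place: 2-amino-2-carboxyethyl in place of amino(carboxy)methyl on a saturated chain carbon bound to a carbonyl carbon. Among the measured compounds shown here, no measured pair differs in just one place, so no step of this kind has been seen; compound 1 and compound 2 differ in several places at once, and their two values together show only what was stated above. For the change from compound 2 to compound 3 no step beyond the scatter is expected in this assay, in either direction. For compound 3 the expected value in this assay is 55000 nM, with a range from 20000 nM to 150000 nM, an expected step of a 1.1-fold lower number from compound 2 to compound 3 (0.02 log units; within the scatter).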

Compound 3, half-maximal effective concentration: 58100 nM
Estimate against measurement, compound 3: 1.1-fold (0.02 log units) below; the range from low to high includes it.
By their numbers in this assay, from the lowest: compounds 3, 2 and 1 (each within the scatter of the next).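

Among the compounds shown here, compound 2 and compound 3 form the first pair that differs in one place, so this position on a saturated chain carbon bound to a carbonyl carbon can now be read directly. In this assay, 2-amino-2-carboxyethyl in place of amino(carboxy)methyl gives a 1.0-fold lower number from compound 2 to compound 3 (0.00 log units; within the scatter), so this one-carbon extension leaves the two numbers indistinguishable, which the comparison of compound 1 with compound 2 could not show. Nothing measured on these compounds offers an explanation for this result.

As far as these compounds go, whether a longer chain such as 4-amino-4-carboxybutyl, or a chain ending in only an amine or only a carboxylic acid, would give a step beyond the scatter remains open. The opposite configuration at the defined stereocentre also remains untested by the compounds shown.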